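The compounds below may be only part of what the source reports. "The series", "measured", "known", "first", "only" and "open" are said of these compounds alone.

In a functional assay for inhibition, read by fluorescence and spectrophotometry, with a stated time of 30 h (a higher number here means a weaker inhibitor, a lower number a stronger inhibitor), compound 1 `COc1ccc(-c2cc(=O)c3ccc(OCCCCN4CCC(CCO)CC4)cc3o2)cc1` gives 38400 nM, and compound 2 `COc1ccc(-c2cc(=O)c3ccc(OCCCCCCN4CCC(C)CC4)cc3o2)cc1` gives 57200 nM, so these two values sit within the scatter of each other. Compound 3 `COc1ccc(-c2cc(=O)c3ccc(OCCCCCCN4CCC(CCO)CC4)cc3o2)cc1` differs from compound 2 by a single change: hydroxymethyl in place of hydrogen on a saturated chain carbon bound to a saturated ring carbon. This produces the 4-(2-hydroxyethyl)piperidin-1-yl group already found in compound 1. Going by the values given here, the only measured step that bears on this is a 1.5-fold higher number from compound 1 to compound 2 (0.17 log units; within the scatter). Among the compounds with values here, that step also alters the chain, so no measured pair isolates the new change. The expected shift in this assay stays within the scatter, with an estimated step of a 1.3-fold lower number from compound 2 to compound 3 (0.10 log units; within the scatter). The estimated value for compound 3 is 45000 nM, with an expected range of 20000 nM to 100000 nM.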

Compound 3, half-maximal inhibitory concentration: 50400 nM
Compound 3: the middle estimate sits 1.1-fold (0.05 log units) below what was measured, and the stated range covers the measured number.
By their numbers in this assay, from the lowest: compounds 1, 3 and 2 (each within the scatter of the next).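

In this assay, the change from 4-methylpiperidin-1-yl to 4-(2-hydroxyethyl)piperidin-1-yl can now be read on its own, as a 1.1-fold lower number from compound 2 to compound 3 (0.05 log units; within the scatter). With that same piperidine group on both compounds, the chain can also be compared alone, as a 1.3-fold higher number from compound 1 to compound 3 (0.12 log units; within the scatter). No measurement shown here accounts for either result.

Going by these compounds, whether an amine or a carboxylic acid in place of the hydroxyl of 2-hydroxyethyl would give a step beyond the scatter remains open. So does the effect of a chain longer than the one in compound 3.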